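From trifluoromethyl to hydroxymethyl: compound 3 to compound 4

The source may hold more compounds than are shown below. What is called first, only, known or untested is meant among the compounds shown, and "the series" means these compounds.

Among the measured compounds shown here, in an in vitro ADME assay on microsomes from liver (Homo sapiens) for metabolic stability, tested at 1 uM (on this read-out lower numbers stand for a shorter-lived compound and higher numbers for a longer-lived compound), compound 3 `Cc1cc(/C=C/C#N)cc(C)c1Oc1cc(Nc2ccc(C#N)cc2)c(N)cc1C(F)(F)F` gives 0.75 h, the second highest of the three numbers so far. Compound 2 `COC(=O)c1cc(N)c(Nc2ccc(C#N)cc2)cc1Oc1c(C)cc(/C=C/C#N)cc1C` is the highest at 4.72 h, and compound 1 `Cc1cc(CCC#N)cc(C)c1Oc1cc(Nc2ccc(C#N)cc2)c(N)cc1CO` the lowest at 0.348 h.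

Compound 4 `Cc1cc(/C=C/C#N)cc(C)c1Oc1cc(Nc2ccc(C#N)cc2)c(N)cc1CO` has not yet been measured. It differs from compound 3 by hydroxymethyl in place of trifluoromethyl on an aromatic carbon.

For the measured compounds named here, the one measured step at this carbon is a 6.3-fold lower number from compound 2 to compound 3 (0.80 log units; beyond the scatter), with trifluoromethyl in place of methoxycarbonyl. It is modest but beyond the scatter, and it shows that a change here can register, though it gives no direction for hydroxymethyl. The closer guide is compound 1, which shares hydroxymethyl with compound 4 but has a different nitrile-bearing chain; compound 1 gives 0.348 h.

The expected step is therefore small and downward, a 1.5-fold lower number from compound 3 to compound 4 (0.18 log units; within the scatter), and is not expected to clear the scatter. For compound 4 the estimate is 0.5 h, with an expected range of 0.22 h to 1.2 h.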

Compound 4, half-life: 0.503 h
For compound 4 the middle estimate is 1.0-fold (0.00 log units) below the measured one, within the range that was stated.
By their numbers in this assay, from the lowest: compounds 1, 4 and 3 (each within the scatter of the next, the first and the last beyond it); then compound 2.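

In this assay, hydroxymethyl and trifluoromethyl at this carbon cannot be told apart (a 1.5-fold lower number from compound 3 to compound 4 (0.17 log units; within the scatter)), whereas replacing methoxycarbonyl with hydroxymethyl gives a step beyond the scatter (a 9.4-fold lower number from compound 2 to compound 4 (0.97 log units; beyond the scatter)), so among these three groups on this core only methoxycarbonyl stands apart from both others. With hydroxymethyl held constant, 2-cyanoethenyl in place of 2-cyanoethyl also stays within the scatter (a 1.4-fold higher number from compound 1 to compound 4 (0.16 log units; within the scatter)), so this change of chain does not register in these two compounds. No measured evidence accounts for any of these steps.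

Still open, from the compounds shown here alone, is whether a carboxylic acid or a primary amide at this carbon would read with methoxycarbonyl or with the other two groups. The compounds shown also leave open whether methoxycarbonyl stands apart in the same way alongside 2-cyanoethyl.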